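The source may hold more compounds than are shown below. What is called first, only, known or untested is meant among the compounds shown, and "the series" means these compounds.

Compound 1 `C/C(=C\CC/C(C)=C/CC[C@@H]1[C@@]2(C)CCC(=O)C(C)(C)[C@H]2CC[C@@]1(C)O)CC/C=C(\C)C(=O)OCc1cn(-c2ccc(F)cc2)nn1` gives > 150000 nM in an ADME assay on L132 cells (Homo sapiens) for cytotoxicity, read by MTT assay, with a stated time of 48 h (on this read-out higher numbers stand for weaker inhibition and lower numbers for stronger inhibition), which is a limit of the assay and not a number.
Compound 2 `C/C(=C\CC/C(C)=C/CC[C@@H]1[C@@]2(C)CCC(=O)C(C)(C)[C@H]2CC[C@@]1(C)O)CC/C=C(\C)C(=O)OCc1cn(-c2ccc(F)c(Cl)c2)nn1` gives > 150000 nM in this assay, again a limit and not a number.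
Among the compounds with values here, compound 3 `C/C(=C\CC/C(C)=C/CC[C@@H]1[C@@]2(C)CCC(=O)C(C)(C)[C@H]2CC[C@@]1(C)O)CC/C=C(\C)C(=O)OCc1cn(-c2cccc(Cl)c2)nn1` gives 94200 nM in this assay, the only number among the three.

Compound 3 differs from compound 2 by hydrogen in place of fluoro on an aromatic carbon. Compound 1 differs from compound 2 by hydrogen in place of chloro on an aromatic carbon, and that gave a step that the two limits leave unreadable from compound 2 to compound 1. Compound 4 `C/C(=C\CC/C(C)=C/CC[C@@H]1[C@@]2(C)CCC(=O)C(C)(C)[C@H]2CC[C@@]1(C)O)CC/C=C(\C)C(=O)OCc1cn(-c2ccccc2)nn1` is still unmeasured and differs from compound 3 by hydrogen in place of chloro on an aromatic carbon; the surroundings are not identical, since in compound 2 the carbon is also ortho to a fluoro group, so this is the same kind of change, not the same one. Two of the three values sit at the limit of > 150000 nM in this assay, at which 2 of the 3 values shown sit. For compound 4 the step is expected to be a 1.6-fold higher number from compound 3 to compound 4 (0.20 log units; within the scatter), resting on a step that the two limits leave unreadable from compound 2 to compound 1 being unreadable. Compound 4 is estimated at 150000 nM, between 60000 nM and 400000 nM.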

Compound 4, half-maximal inhibitory concentration: > 150000 nM
Compound 4: only a limit was reported; the forecaster's own chance of this, stated with the estimate: 55%; the middle value sits exactly at the limit.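

In this assay compound 4 gives > 150000 nM, which is a limit of the assay and not a number. Replacing chloro with hydrogen gives an at least 1.5-fold higher number from compound 3 to compound 4 (0.20 log units; that floor lies within the scatter), so even this smallest possible step does not clear the usual scatter. The same replacement from compound 2 to compound 1, in the presence of fluoro, cannot be read, and neither can the other steps to compound 4, so nothing here shows whether the change carries from one setting to another, as most values sit at one limit: the limit of > 150000 nM in this assay, at which 3 of the 4 values shown sit.

As far as these compounds go, what an amine or a methoxy group on the phenyl group would give remains open. So does the effect of this replacement on a different core.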